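Furan-2-yl in Place of Dichlorophenyl on the Ring Amine

The source may hold more compounds than are shown below. What is called first, only, known or untested is meant among the compounds shown, and "the series" means these compounds.

Compound 1 `CCCCNc1nc(N)nc2c1CN(Cc1cccc(OC)c1Cl)CC2` — 0.04 uM
Compound 2 `CCCCNc1nc(N)nc2c1CN(Cc1cccc(Cl)c1Cl)CC2` — 0.18 uM
Compound 3 `CCCCNc1nc(N)nc2c1CN(Cc1cccc3ccccc13)CC2` — 0.43 uM

In an assay on HEK293 cells for agonist activity at Toll-like receptor 8 (Homo sapiens), read by a luciferase reporter, with a stated time of 6 h (on this read-out higher numbers stand for an effect only at larger amounts of compound and lower numbers for an effect already at smaller amounts), compound 2 gives 0.18 uM, the second highest of the three numbers; compound 3 gives 0.43 uM and compound 1 gives 0.04 uM. Compound 4 `CCCCNc1nc(N)nc2c1CN(Cc1ccco1)CC2` differs from compound 2 by furan-2-yl in place of 2,3-dichlorophenyl on a saturated chain carbon bound to an amine nitrogen in a ring. Going by the values given here, the only measured step, a 4.5-fold higher number from compound 1 to compound 2 (0.65 log units; beyond the scatter), concerns one substituent on an aromatic ring that here leaves as a whole, so no step bears directly on this change; the values of compound 2 and compound 3 only show that the shared core tolerates different aromatic groups at this place with numbers beyond the scatter apart. Compound 4 is therefore expected at 0.6 uM, within 0.15 uM to 2.5 uM. This corresponds to an expected 3.3-fold higher number from compound 2 to compound 4 (0.52 log units; beyond the scatter).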

Compound 4, minimum effective concentration: 0.08 uM
Beside the measured number, compound 4's estimate is 7.5-fold (0.88 log units) above it, and the stated range ends above it.
By their numbers in this assay, from the lowest: compounds 1 and 4 (each within the scatter of the next); then compound 2; then compound 3.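

In this assay, furan-2-yl in place of 2,3-dichlorophenyl on a saturated chain carbon bound to an amine nitrogen in a ring gives a 2.3-fold lower number from compound 2 to compound 4 (0.35 log units; beyond the scatter). This place therefore does not require a six-membered aromatic ring of carbon only or its two chlorines, since a five-membered aromatic ring with 1 hetero atom and fewer heavy atoms also gives a low number. Nothing shown accounts for this step. Still open, from the compounds shown here alone, is whether thiophen-2-yl, pyridin-2-yl or cyclopentyl would read like furan-2-yl here, and what a methyl group on the furan ring would do.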